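Epimer at the tertiary carbinol of a pepsin inhibitor

This account rests on a few compounds, and the source may have more. Where it says the series, first, only, none or still open, it means among the compounds named here.

This account concerns a pair of peptide-like inhibitors and a third analogue still to be measured. Compound 1, `CC(C)CCNC(=O)[C@H](C)NC(=O)C[C@H](O)[C@H](CC(C)C)NC(=O)[C@@H](NC(=O)[C@@H](NC(=O)OCCC(C)C)C(C)C)C(C)C`, carries a secondary alcohol on the central chain and, in an assay on isolated protein for inhibition of Pepsin A (Homo sapiens) (on this read-out higher numbers stand for weaker inhibition and lower numbers for stronger inhibition), gives 0.1 nM. Compound 2, `CC(C)CCNC(=O)[C@H](C)NC(=O)C[C@](C)(O)[C@H](CC(C)C)NC(=O)[C@@H](NC(=O)[C@@H](NC(=O)OCCC(C)C)C(C)C)C(C)C`, bears a methyl group on that carbinol carbon and, in this assay, gives 1200 nM, the highest of the two numbers and far above the value of compound 1. Compound 3, `CC(C)CCNC(=O)[C@H](C)NC(=O)C[C@@](C)(O)[C@H](CC(C)C)NC(=O)[C@@H](NC(=O)[C@@H](NC(=O)OCCC(C)C)C(C)C)C(C)C`, is its epimer: the two compounds have the same atoms and bonds and differ only in configuration as drawn: 1 of 5 stereo elements differ; a stereocentre at a saturated chain carbon is drawn S in compound 2 and R in compound 3. Because compound 2 gives 1200 nM and so stands far from compound 1, there is room for the other configuration to recover much of the lost inhibition, and it is expected that the step from compound 2 to compound 3 will be downward and well beyond the scatter, a 60-fold lower number from compound 2 to compound 3 (1.78 log units; beyond the scatter). The estimate for compound 3 in this assay is therefore 20 nM, with a range from 1 nM to 500 nM, reflecting the uncertainty of how much the reversed configuration alone restores.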

Compound 3, inhibition constant: 1.5 nM
Estimate against measurement, compound 3: 13-fold (1.12 log units) above; the measured number falls inside the stated range.
By their numbers in this assay, from the lowest: compound 1; then compound 3; then compound 2.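

In this assay, the carbinol carbon that bears the methyl group proves highly sensitive to its configuration: reversing it gives an 800-fold lower number from compound 2 to compound 3 (2.90 log units; beyond the scatter). The size of this step can be laid to configuration alone, because of what separates the two compounds: the fact that compounds 2 and 3 differ only in the configuration as drawn Even with the configuration of compound 3, methyl in place of hydrogen on this carbon is not neutral, giving a 15-fold higher number from compound 1 to compound 3 (1.18 log units; beyond the scatter), although this step is much the smaller of the two, so a methyl group at this position is compatible with low-nanomolar inhibition only in one of its two configurations.

The compounds shown carry only hydrogen or methyl on this carbon, so it remains open whether an ethyl group or a longer chain would be accepted there, and whether the same dependence on configuration would hold for it. They also leave open what would follow if an amine took the place of the hydroxyl group on this carbon, and whether the preference for one configuration extends beyond this assay.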